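This account rests on a few compounds, and the source may have more. Where it says the series, first, only, none or still open, it means among the compounds named here.

Compound 3 `C=CCn1c(=O)/c(=C\c2ccc(F)c(Br)c2)[nH]c(=O)/c1=C\c1ccccc1OC` is one of three measured members of this series. In a functional assay on HeLa cells (Homo sapiens) for cytotoxicity, read by CCK-8 assay, with a stated time of 72 h (a lower number here means a stronger inhibitor, a higher number a weaker inhibitor), compound 1 `COc1ccccc1/C=c1\c(=O)[nH]/c(=C/c2cccc(Cl)c2Cl)c(=O)n1C` gives 200 nM and compound 2 `COc1ccccc1/C=c1\c(=O)[nH]/c(=C/c2ccccc2Cl)c(=O)n1C` gives 300 nM; the step of a 1.5-fold higher number from compound 1 to compound 2 (0.18 log units; within the scatter) shows that dropping one chloro group changes little. Compound 3, by contrast, is reported in this assay as "not active" (no number reported), so no single number places it. Compound 4 `C=CCn1c(=O)/c(=C\c2ccccc2F)[nH]c(=O)/c1=C\c1ccccc1OC` differs from compound 3 by 2-fluorophenyl in place of 3-bromo-4-fluorophenyl on a double-bonded chain carbon bound to an aromatic carbon. For the measured compounds named here, no measured step touches this exact exchange; the only step recorded, between compound 1 and compound 2, lies within the scatter. The direction for compound 4 is therefore uncertain, and the estimate for compound 4 in this assay is 3000 nM, with a range from 300 nM to 30000 nM.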

Compound 4, half-maximal inhibitory concentration: 45000 nM
Estimate against measurement, compound 4: 15-fold (1.18 log units) below, and the stated range ends below it.
By their numbers in this assay, from the lowest: compounds 1 and 2 (each within the scatter of the next); then compound 4.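

In this assay compound 3 has no number and compound 4 gives 45000 nM so no step can be read between them. From the compounds shown here alone, what exchanging 3-bromo-4-fluorophenyl for 2-fluorophenyl does to the read-out stays open. Nothing shown bears on the result for compound 4.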